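The source may report more compounds than this note shows. Statements on the series, on what has been measured and on what is new or still open speak of the compounds shown alone.

Measured in an ADME assay on the whole organism with Oryza sativa as the target, tested at 10 uM; a lower number here means a stronger effect, a higher number a weaker effect of the compound at the concentration tested: compound 1 `CCc1cccc(NC(=O)N[C@@H](C)c2ccccc2)c1` gives 86%; compound 2 `C[C@@H](NC(=O)Nc1cccc(C(F)(F)F)c1)c1ccccc1` gives 70%.

Compound 2 stands lowest of the two numbers, with compound 1 sitting higher by a gap beyond the usual scatter. Compound 3 `C[C@H](NC(=O)Nc1cccc(C(F)(F)F)c1)c1ccccc1` has not yet been measured in this assay. It differs from compound 2 as follows: the two compounds have the same atoms and bonds and differ only in configuration as drawn: 1 of 1 stereo elements differ; a stereocentre at a saturated chain carbon is drawn R in compound 2 and S in compound 3. For the measured compounds named here, no pair of measured compounds shows what such a change does here, so the step is expected to be small and its direction left open. Compound 3 is therefore estimated at 75%, within 55% to 95%. The expected step is a number 5 percentage points higher from compound 2 to compound 3 (within the scatter).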

Compound 3, a percentage reported as activity, at one concentration (the size of the read-out at that concentration, not a potency): 92%
Compound 3: middle estimate off by 17 percentage points, on the low side; the range from low to high includes it.
By their numbers in this assay, from the lowest: compound 2; then compounds 1 and 3 (each within the scatter of the next).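

Inverting the stereocentre at the saturated chain carbon from R to S gives a number 22 percentage points higher from compound 2 to compound 3 (beyond the scatter) in this assay, so configuration at this position can shift the read-out on its own. That step can be assigned to the stereocentre alone because no other part of the structure changes: the fact that compounds 2 and 3 differ only in the configuration as drawn. In the S series, trifluoromethyl in place of ethyl on an aromatic carbon gives only a number 6 percentage points higher from compound 1 to compound 3 (within the scatter), so this exchange shows no clear effect. As far as these compounds go, whether the same stereocentre inversion matters with ethyl, or with a nitrile or a carboxylic acid on that aromatic carbon, remains open.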